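A few compounds are considered here, and "the series" means these few. Any claim that something is new, unique, unknown or untested is made for them only; others in the source may bear on it.

Compound 1 `CCOC(=O)/C=C/c1ccc(NC(=O)C2(NC(=O)c3ccc4c(C5CCCC5)c(-c5ncc(Cl)cn5)n(C)c4c3)CCC2)cc1OCC`: > 5 h
Compound 2 `CCOc1cc(NC(=O)C2(NC(=O)c3ccc4c(C5CCCC5)c(-c5ncc(Cl)cn5)n(C)c4c3)CCC2)ccc1/C=C/C(=O)OCc1ccccc1`: > 5 h

Within the data shown here, both compounds have been measured in an ADME assay (intestine, Homo sapiens) for pharmacokinetics, using microsomes; a lower number here means that the compound disappears faster, a higher number that the compound lasts longer. Compound 1 gives > 5 h, which is a limit of the assay and not a number. Compound 2 gives > 5 h, also a limit. Compound 2 therefore stands at the limit, and its value cannot be ordered against that of compound 1. Among the measured compounds shown here, the single measured step, a step that the two limits leave unreadable from compound 1 to compound 2, is unreadable, and the limit of > 5 h in this assay, at which 2 of the 2 values shown sit, is the only evidence available.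

Compound 3 `CCOc1cc(NC(=O)C2(NC(=O)c3ccc4c(C5CCCC5)c(-c5ncc(Cl)cn5)n(C)c4c3)CCC2)ccc1/C=C/C(=O)OCC(=O)N1CCOCC1` differs from compound 2 by (morpholin-4-yl)carbonyl in place of phenyl on a saturated chain carbon bound to an oxygen next to a carbonyl group. For the measured compounds named here, no measured step bears on this change; the step that the two limits leave unreadable from compound 1 to compound 2 concerns a different group and gives no size. The expectation for compound 3 can rest only on where compound 2 stands, so the expected step is a number no higher from compound 2 to compound 3 (the limit leaves the size open). Compound 3 is estimated at 5 h, with a range from 2 h to 10 h.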

Compound 3, half-life: 3.42 h
The estimate for compound 3 lay 1.5-fold (0.16 log units) above the measured number; the range from low to high includes it.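

Among these compounds, compound 3 is the first compound at this position to give a number rather than a limit in this assay, and the other values shown offer only this: the limit of > 5 h in this assay, at which 2 of the 3 values shown sit. The change from phenyl to (morpholin-4-yl)carbonyl can now be read as an at least 1.4-fold lower number from compound 2 to compound 3 (0.16 log units; that floor lies within the scatter), and the change from methyl to the same group as an at least 1.4-fold lower number from compound 1 to compound 3 (0.16 log units; that floor lies within the scatter). Both steps are floors that do not clear the scatter, so this position may tolerate either change with little effect or with a larger one, while the step between the two limits cannot be read.

The compounds shown leave open the true size of both steps. They also leave open how an amine or a carboxylic acid on the same saturated chain carbon would read in this assay.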